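A Bromine Moved on the Aryl Group of Compound 2

The compounds below may be only part of what the source reports. "The series", "measured", "known", "first", "only" and "open" are said of these compounds alone.

Compound 2 `CCCn1c(=O)[nH]c2nc(-c3ccc(S(=O)(=O)N4CCN(c5ccc(Br)cc5)CC4)cc3)[nH]c2c1=O` is one of three close analogues that share a common core and differ only in the aryl group carried on the ring nitrogen. In an assay on CHO cells for displacement of a labelled ligand from adenosine receptor A1 (Homo sapiens), read by scintillation counting, with a stated time of 90 min, in the presence of a further agent that is not named here (a higher number here means a weaker inhibitor, a lower number a stronger inhibitor), compound 2 gives > 1000 nM, which is a limit of the assay rather than a measured number. Compound 1 `CCCn1c(=O)[nH]c2nc(-c3ccc(S(=O)(=O)N4CCN(c5ccc(F)cc5)CC4)cc3)[nH]c2c1=O` gives > 1000 nM in this assay, likewise a limit. Compound 3 `CCCn1c(=O)[nH]c2nc(-c3ccc(S(=O)(=O)N4CCN(c5ccccc5Br)CC4)cc3)[nH]c2c1=O` gives > 1000 nM in this assay, again a limit. All three values therefore rest at the limit of > 1000 nM in this assay, at which 3 of the 3 values shown sit, and none of the steps among them can be read: a step that the two limits leave unreadable from compound 1 to compound 2, a step that the two limits leave unreadable from compound 1 to compound 3 and a step that the two limits leave unreadable from compound 2 to compound 3 are each unreadable.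

Compound 4 `CCCn1c(=O)[nH]c2nc(-c3ccc(S(=O)(=O)N4CCN(c5cccc(Br)c5)CC4)cc3)[nH]c2c1=O` is the next member of the series. Its change from compound 2 is 3-bromophenyl in place of 4-bromophenyl on an amine nitrogen in a ring. Among the measured compounds shown here, the step that comes closest to it is the one from compound 2 to compound 3, which also moves the bromine to another place on the aryl group, yet its size is not readable. With every neighbour at the limit, he expects compound 4 to stay in the same region, an expected step that the limit leaves unreadable from compound 2 to compound 4 with nothing beyond the scatter. His estimate for compound 4 in this assay is 2500 nM, with a range from 900 nM to 10000 nM.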

Compound 4, inhibition constant: > 1000 nM
Compound 4: a limit, no number (the forecaster's own chance of this, stated with the estimate: 85%); the middle value is on the limit's open side.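

In this assay compound 4 gives > 1000 nM as a limit of the assay and not a number. Among the compounds shown here, no new step from compound 1, compound 2 or compound 3 to compound 4 can be read, since all four compounds rest at one limit: the limit of > 1000 nM in this assay, at which 4 of the 4 values shown sit.

The compounds shown leave open how strong an inhibitor any of them is, and whether moving the bromine on the aryl group changes that at all.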